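Taking the Chloro Group off Compound 3

The source may report more compounds than this note shows. Statements on the series, on what has been measured and on what is new or still open speak of the compounds shown alone.

In a functional assay on MCF7 cells (Homo sapiens) for cytotoxicity, read by MTT assay, with a stated time of 24 h (a higher number here means a weaker inhibitor, a lower number a stronger inhibitor), compound 3 (`O=C(Nc1ccc(Cl)c(C(F)(F)F)c1)Nc1cccc2c(Oc3ccc([N+](=O)[O-])cc3)cccc12`) gives 953 nM and stands level with compound 1 (`COc1ccc(NC(=O)Nc2cccc3c(Oc4ccc([N+](=O)[O-])cc4)cccc23)cc1`) at 953 nM and compound 2 (`CC(=O)Nc1ccc(Oc2cccc3c(NC(=O)Nc4cccc(C(F)(F)F)c4)cccc23)cc1`) at 953 nM on these numbers. Compound 4 (`O=C(Nc1cccc(C(F)(F)F)c1)Nc1cccc2c(Oc3ccc([N+](=O)[O-])cc3)cccc12`) differs from compound 3 by hydrogen in place of chloro on an aromatic carbon and so carries 3-(trifluoromethyl)phenyl. Within the data shown here, the one measured step bearing on this, 4-chloro-3-(trifluoromethyl)phenyl in place of 4-methoxyphenyl, shows no change at the digits printed from compound 1 to compound 3 (within the scatter) and compound 2, which also carries 3-(trifluoromethyl)phenyl, holds 953 nM as well. No step beyond the scatter is therefore expected in this assay for this change. The expected step is no change at the digits printed from compound 3 to compound 4 (within the scatter) on this reading. Compound 4 is estimated at 953 nM (range 480 nM to 1900 nM).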

Compound 4, half-maximal inhibitory concentration: 953 nM
Compound 4: middle estimate and measured number agree at the digits printed, and the stated range covers the measured number.
By their numbers in this assay, from the lowest: compounds 1, 2, 3 and 4 (each within the scatter of the next).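

In this assay, among these compounds, hydrogen in place of chloro gives no change at the digits printed from compound 3 to compound 4 (within the scatter) here, the first direct reading of this position on the ring bearing trifluoromethyl. The other two new comparisons read the same way: nitro in place of acetamido gives no change at the digits printed from compound 2 to compound 4 (within the scatter) and 3-(trifluoromethyl)phenyl in place of 4-methoxyphenyl gives no change at the digits printed from compound 1 to compound 4 (within the scatter) in this small set. No supporting measurement explains why all these steps are flat.

As far as these compounds go, whether an amine or a carboxylic acid at this position would shift the reading beyond the scatter remains open.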